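The source may report more compounds than this note shows. Statements on the series, on what has been measured and on what is new or still open speak of the compounds shown alone.

Measured in a functional assay on HepG2 cells (Homo sapiens) for cytotoxicity, read by MTT assay, with a stated time of 24 h; a higher number here means a weaker inhibitor, a lower number a stronger inhibitor:
- compound 1 `O=C1/C(=C/c2ccccc2F)CN(S(=O)(=O)c2ccc(F)cc2)C/C1=C\c1ccccc1F`: 7220 nM
- compound 2 `COc1cc(/C=C2\CN(S(=O)(=O)c3ccc(F)cc3)C/C(=C\c3cc(OC)c(OC)c(OC)c3)C2=O)cc(OC)c1OC`: 4200 nM
- compound 3 `COc1cc(/C=C2\CN(S(=O)(=O)c3ccc(F)cc3)C/C(=C\c3cc(OC)cc(OC)c3)C2=O)cc(OC)c1`: 8100 nM

The three values lie within the usual scatter of one another, so compound 1 is not separated from either compound 2 or compound 3 in this assay.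

The next compound to be tested is compound 4 `CC(=O)Nc1ccc(S(=O)(=O)N2C/C(=C\c3ccccc3F)C(=O)/C(=C/c3ccccc3F)C2)cc1`. It differs from compound 1 in one place: acetamido stands in place of fluoro on an aromatic carbon, para to a large group (acetamido in place of fluoro on an aromatic carbon). The same difference can be read as 4-fluorophenyl to 4-acetamidophenyl.

Among the measured compounds shown here, no two measured compounds differ in only one place, so the data hold no direct precedent for this change. The expectation therefore starts from compound 1 at 7220 nM, and no step beyond the scatter is expected in this assay, in either direction. The expected change is a 1.1-fold lower number from compound 1 to compound 4 (0.05 log units; within the scatter). For compound 4 the estimated value is 6500 nM, with an expected range of 2500 nM to 18000 nM.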

Compound 4, half-maximal inhibitory concentration: 5840 nM
Beside the measured number, compound 4's estimate is 1.1-fold (0.05 log units) above it, within the range that was stated.
By their numbers in this assay, from the lowest: compounds 2, 4, 1 and 3 (each within the scatter of the next).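

In this assay, among the compounds shown here, the first comparison in this set that differs in only one place, acetamido in place of fluoro on an aromatic carbon gives a 1.2-fold lower number from compound 1 to compound 4 (0.09 log units; within the scatter). The position para to a large group therefore takes a larger group, one with a hydrogen-bond donor and a hydrogen-bond acceptor where fluoro has neither, with no step beyond the scatter in this assay. Nothing available explains this outcome.

From the compounds shown here alone, whether an amine or a carboxylic acid at this position would also stay within the scatter of compound 1 remains open. Going by these compounds, it is also open whether acetamido in place of fluoro would give a similar step on the cores of compound 2 and compound 3.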